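Carbamoyl for 3-Fluorophenyl on a Pyrazole Acid Core

The compounds below may be only part of what the source reports. "The series", "measured", "known", "first", "only" and "open" are said of these compounds alone.

Measured compounds:
compound 1 `Cc1n[nH]c(C(=O)O)c1Cc1cccc(-c2cccc(F)c2)c1`: 500 nM
compound 2 `Cc1n[nH]c(C(=O)O)c1Cc1ccc(Oc2ccccc2)cc1`: 500 nM
compound 3 `Cc1n[nH]c(C(=O)O)c1Cc1ccccc1C(F)(F)F`: 1300 nM

Of the compounds shown here, three sharing the core of compound 1 have been tested in an assay on isolated protein for inhibition of 2-Hydroxyacid oxidase 2 (Rattus norvegicus); on this read-out lower numbers stand for stronger inhibition and higher numbers for weaker inhibition. Compound 1 gives 500 nM and stands level with compound 2, which in this assay gives 500 nM; the two together sit at the lowest of the three numbers, with no difference between them beyond the scatter. Compound 3 in this assay gives 1300 nM, a higher number than that of compound 1 and beyond the scatter.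

Compound 4 `Cc1n[nH]c(C(=O)O)c1Cc1cccc(C(N)=O)c1` has not yet been measured. It arises from compound 1 by one change: carbamoyl in place of 3-fluorophenyl on an aromatic carbon. For the measured compounds named here, no measured pair among the three compounds makes this kind of change, so nothing among them tells directly how the number will move. The two lowest numbers belong to compounds carrying a second aromatic ring on the benzylic ring, which compound 4 no longer has. Compound 4 is therefore expected to give a higher number than compound 1, a step of a 4.0-fold higher number from compound 1 to compound 4 (0.60 log units; beyond the scatter) in this assay. The estimate for compound 4 is 2000 nM, within a range from 600 nM to 7000 nM.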

Compound 4, half-maximal inhibitory concentration: 900 nM
Beside the measured number, compound 4's estimate is 2.2-fold (0.35 log units) above it, and the stated range covers the measured number.
By their numbers in this assay, from the lowest: compounds 1, 2, 4 and 3 (each within the scatter of the next, the first and the last beyond it).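

In this assay, carbamoyl in place of 3-fluorophenyl gives a 1.8-fold higher number from compound 1 to compound 4 (0.26 log units; within the scatter) and so leaves the number within the scatter. For the compounds shown here, this is the first single-place comparison, and it shows that, on this aromatic carbon, the second aromatic ring of compound 1 can give way to a smaller group with no ring without a change beyond the scatter. Going by these compounds alone, it also shows that the second aromatic ring is not needed here for a number in this range, although the earlier compounds had left that possibility open. No measurement at hand bears on why the two groups give numbers within the scatter of each other.

This single pair leaves open whether a nitrile, a carboxylic acid or an amine on the same carbon would also stay within the scatter. It also leaves open whether a methyl group on the carbamoyl nitrogen would shift the number.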